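Free fraction after a ring change on the carbamate side

The compounds below may be only part of what the source reports. "The series", "measured", "known", "first", "only" and "open" are said of these compounds alone.

Values measured in an ADME assay on the whole organism (plasma, Homo sapiens) for protein binding, read by LC-MS, with a stated time of 24 h (on this read-out lower numbers stand for a smaller free fraction and higher numbers for a larger free fraction), are as follows.
- Compound 1 `CN(CC1CCC1)C(=O)OCc1c(-c2ccc(O[C@H]3CCC[C@H](C(=O)O)C3)c(C(F)F)n2)nnn1C` gives 0.001
- Compound 2 `Cc1nc(-c2nnn(C)c2COC(=O)N(C)CC2CCC2)ccc1O[C@H]1CCC[C@H](C(=O)O)C1` gives 0.033

Of the two numbers, the higher belongs to compound 2 and the lower to compound 1. Compound 3 `Cc1nc(-c2nnn(C)c2COC(=O)N(C)CC2CCCC2)ccc1O[C@H]1CCC[C@H](C(=O)O)C1` differs from compound 2 by cyclopentyl in place of cyclobutyl on a saturated chain carbon bound to an amide-type nitrogen. Within the data shown here, no measured step involves this change, so the data give no direct size for it. Among the measured compounds shown here, the only measured step, with methyl in place of difluoromethyl on an aromatic carbon, is a 33-fold higher number from compound 1 to compound 2 (1.52 log units; beyond the scatter) and it bears on compound 3 only indirectly, as a reminder that one change moved this number far and that the expected range should stay wide. In this assay a small move towards a lower number is expected, a judgement and not a measured trend, and the estimated size is a 1.5-fold lower number from compound 2 to compound 3 (0.18 log units; within the scatter) at most a modest step. The estimate for compound 3 is 0.022 (expected range 0.008 to 0.05).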

Compound 3, unbound fraction: 0.012
The estimate for compound 3 lay 1.8-fold (0.26 log units) above the measured number, and the stated range covers the measured number.
By their numbers in this assay, from the lowest: compound 1; then compound 3; then compound 2.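

In this assay, the side of the molecule carrying the carbamate proves able to shift the number by itself: cyclopentyl in place of cyclobutyl, on a saturated chain carbon bound to an amide-type nitrogen, gives a step beyond the scatter (a 2.8-fold lower number from compound 2 to compound 3 (0.44 log units; beyond the scatter)). Among these compounds, until now the only change on record sat on an aromatic carbon, where methyl in place of difluoromethyl gave a large rise (a 33-fold higher number from compound 1 to compound 2 (1.52 log units; beyond the scatter)); the new step is modest by comparison, runs towards a smaller free fraction, and comes from a swap between two carbon-only rings, neither with hydrogen-bond donors or acceptors. Nothing available here accounts for the drop.

With only these two rings at this position, a single step cannot show whether the number keeps falling with cyclohexyl, or how an open chain such as isobutyl or an oxygen-containing ring such as tetrahydropyranyl would compare. As far as these compounds go, it also remains open whether cyclopentyl would shift the number to a similar extent on the core that carries difluoromethyl, where compound 1 already stands at the low end of the series.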